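A further trifluoromethyl on compound 2

This account rests on a few compounds, and the source may have more. Where it says the series, first, only, none or still open, it means among the compounds named here.

In a functional assay on DU-145 cells (Homo sapiens) for antiproliferative activity, read by propidium iodide staining, with a stated time of 96 h (a lower number here means a stronger inhibitor, a higher number a weaker inhibitor), compound 1 (`CC(O)(COc1ccc(C(F)(F)F)cc1)C(=O)Nc1cccc(S(F)(F)(F)(F)F)c1`) gives 13600 nM and compound 2 (`CC(O)(COc1cccc(C(F)(F)F)c1)C(=O)Nc1cccc(S(F)(F)(F)(F)F)c1`) gives 31700 nM, so compound 2 holds the higher, weaker number of the two. Among the compounds with values here, the only measured step, a 2.3-fold higher number from compound 1 to compound 2 (0.37 log units; beyond the scatter), is modest but beyond the scatter. Compound 3 (`CC(O)(COc1cc(C(F)(F)F)cc(C(F)(F)F)c1)C(=O)Nc1cccc(S(F)(F)(F)(F)F)c1`) differs from compound 2 in one place: trifluoromethyl in place of hydrogen on an aromatic carbon. It carries trifluoromethyl in place of hydrogen on an aromatic carbon, meta to a trifluoromethyl group. The measured step bears on this change only indirectly, since it alters where a single trifluoromethyl group sits and adds none. Within the data shown here, no measured pair shows the effect of adding such a group, so the direction remains uncertain. A modest step toward a lower number is nevertheless expected, of a size similar to a 2.3-fold higher number from compound 1 to compound 2 (0.37 log units; beyond the scatter), with compound 2 at 31700 nM being the weaker of the two measured compounds. In this assay, compound 3 is estimated at 15000 nM, with an expected range of 6000 nM to 40000 nM. This estimate means an expected 2.1-fold lower number from compound 2 to compound 3 (0.32 log units; beyond the scatter).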

Compound 3, half-maximal inhibitory concentration: 9300 nM
For compound 3 the middle estimate is 1.6-fold (0.21 log units) above the measured one; low and high end bracket the measured number.
By their numbers in this assay, from the lowest: compounds 3 and 1 (each within the scatter of the next); then compound 2.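

In this assay, within the data shown here, the change from hydrogen to trifluoromethyl gives a 3.4-fold lower number from compound 2 to compound 3 (0.53 log units; beyond the scatter) and is the first measured case of a group being added to this ring. The earlier step, a 2.3-fold higher number from compound 1 to compound 2 (0.37 log units; beyond the scatter), only moved a single trifluoromethyl group, so it could not show what a further group does; this one shows that 4 more heavy atoms on this aromatic carbon, meta to a trifluoromethyl group, go with a lower number and thus a stronger inhibitor in these cells. No supporting measurement is available to explain this shift, so it stands as an observed change in the antiproliferative read-out alone.

The compounds shown leave open whether this lower number is specific to trifluoromethyl or would also follow from another group at the same place, such as a chlorine atom, a methoxy group or a nitrile. They also leave open whether the step would keep its direction and size if the pentafluorosulfanyl group, which all three compounds share, gave way to a group such as a carboxylic acid or an amine.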